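Swapping the halogenated ring of compound 2

The source may report more compounds than this note shows. Statements on the series, on what has been measured and on what is new or still open speak of the compounds shown alone.

Among the compounds with values here, in a functional assay on CCRF-CEM cells (Homo sapiens) for antiproliferative activity, with a stated time of 72 h (on this read-out lower numbers stand for stronger inhibition and higher numbers for weaker inhibition), compound 2 `OC[C@H]1O[C@@H](n2cnc3c(NCc4ccc(F)c(Cl)c4)ncnc32)[C@H](O)[C@@H]1O` gives 3400 nM and holds the lower of the two numbers so far, while compound 1 `Cc1cccc(CNc2ncnc3c2ncn3[C@@H]2O[C@H](CO)[C@@H](O)[C@H]2O)c1` gives 19100 nM as the other. Compound 3 `Cc1ccc(O)c(CNc2ncnc3c2ncn3[C@@H]2O[C@H](CO)[C@@H](O)[C@H]2O)c1` differs from compound 2 by 2-hydroxy-5-methylphenyl in place of 3-chloro-4-fluorophenyl on a saturated chain carbon bound to a nitrogen on an aromatic ring with 2-hydroxy-5-methylphenyl in place of 3-chloro-4-fluorophenyl on a saturated chain carbon bound to a nitrogen on an aromatic ring. Within the data shown here, the one measured step that bears on this is a 5.6-fold lower number from compound 1 to compound 2 (0.75 log units; beyond the scatter) for 3-chloro-4-fluorophenyl replacing 3-methylphenyl. Among the measured compounds shown here, compound 3 also has a methyl and no halogen, although no measured compound shows what its hydroxy does, so a partial or full reversal of that modest step is expected. The expected change is a 2.6-fold higher number from compound 2 to compound 3 (0.42 log units; beyond the scatter) toward weaker inhibition. The expected value for compound 3 is 9000 nM with 2500 nM to 30000 nM as its estimated range.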

Compound 3, half-maximal inhibitory concentration: 1900 nM
Beside the measured number, compound 3's estimate is 4.7-fold (0.68 log units) above it; measured number below the stated range.
By their numbers in this assay, from the lowest: compounds 3 and 2 (each within the scatter of the next); then compound 1.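

A halogen is not required for a low number at this position: the step from the halogenated ring to 2-hydroxy-5-methylphenyl is a 1.8-fold lower number from compound 2 to compound 3 (0.25 log units; within the scatter) and leaves the two rings level. The hydroxy alone, added to the ring of compound 1, gives a 10-fold lower number from compound 1 to compound 3 (1.00 log units; beyond the scatter) and so accounts for a gain as large as the halogens gave. Nothing available explains this gain. Going by these compounds, whether a methoxy or an amine in place of the hydroxy would serve equally stays open. So does whether a hydroxy on the halogenated ring of compound 2 would add to its activity.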